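Chloro and methyl on the phenyl ether of a triazine

The compounds below may be only part of what the source reports. "The series", "measured", "known", "first", "only" and "open" are said of these compounds alone.

Measured compounds:
- compound 1, `CN1CCN(c2nc(N)nc(COc3ccccc3)n2)CC1`: 9530 nM
- compound 2, `CN1CCN(c2nc(N)nc(COc3cccc(Cl)c3)n2)CC1`: 5820 nM

In an assay on HEK293 cells for displacement of a labelled ligand from 5-hydroxytryptamine receptor 7 (Homo sapiens), read by radioligand binding, with a stated time of 1 h (a lower number here means a stronger inhibitor, a higher number a weaker inhibitor), compound 1 gives 9530 nM, the higher of the two measured values, and compound 2 gives 5820 nM. The step of a 1.6-fold lower number from compound 1 to compound 2 (0.21 log units; within the scatter) introduces a chloro in place of hydrogen on an aromatic carbon of the phenyl ether and does not leave the scatter.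

Compound 3, `Cc1cc(OCc2nc(N)nc(N3CCN(C)CC3)n2)ccc1Cl`, is not yet measured. It differs from compound 1 as follows: 4-chloro-3-methylphenyl in place of phenyl on an oxygen on a saturated carbon. Among the measured compounds shown here, only the step from compound 1 to compound 2 bears on this change, since it also places a chlorine on that phenyl ring; it was small. For the measured compounds named here, compound 3 adds a methyl as well, and no measured pair speaks to that addition. A modest lowering of the number is therefore expected, with a fair chance that the step is no larger than the scatter.

Compound 3 is estimated at 5000 nM, with a range from 2000 nM to 12000 nM, which is the expected step of a 1.9-fold lower number from compound 1 to compound 3 (0.28 log units; within the scatter).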

Compound 3, inhibition constant: 5840 nM
Compound 3: the middle estimate sits 1.2-fold (0.07 log units) below what was measured; low and high end bracket the measured number.
By their numbers in this assay, from the lowest: compounds 2, 3 and 1 (each within the scatter of the next).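

In this assay, among the compounds shown here, putting 4-chloro-3-methylphenyl in place of phenyl on the oxygen gives a 1.6-fold lower number from compound 1 to compound 3 (0.21 log units; within the scatter), so a ring carrying both chloro and methyl still does not leave the scatter, which the single chloro of compound 2 could not show. Against 3-chlorophenyl, the same group gives a 1.0-fold higher number from compound 2 to compound 3 (0.00 log units; within the scatter), so across the three compounds shown, this place on an oxygen on a saturated carbon accepts these changes to the phenyl ring without any step that can be told from the scatter. No further measurement bears on this result.

The compounds shown leave open whether anything on this ring can move the number beyond the scatter, for instance an amine or a carboxylic acid in place of the chloro or the methyl, or a longer chain in place of the saturated carbon that links the oxygen to the core. For the compounds shown here, they also do not separate the chloro from the methyl within 4-chloro-3-methylphenyl, since no compound here carries that methyl alone or that chloro alone.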